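Changing One Group on the Shared Core: Compound 4

This account rests on a few compounds, and the source may have more. Where it says the series, first, only, none or still open, it means among the compounds named here.

Measured in a functional assay on B16-F0 cells (Mus musculus) for inhibition, read by CCK-8 assay, with a stated time of 48 h; on this read-out higher numbers stand for weaker inhibition and lower numbers for stronger inhibition:
Compound 1 `COc1cc(-c2ccnc3cc(-c4ccc(C)cc4)nn23)cc(OC)c1OC`: 21 nM
Compound 2 `COc1cc(-c2ccnc3cc(-c4ccc(C(C)(C)C)cc4)nn23)cc(OC)c1OC`: > 10000 nM
Compound 3 `COc1cc(-c2ccnc3cc(-c4ccc(-c5cnn(C)c5)cc4)nn23)cc(OC)c1OC`: 1240 nM

Among the numbers shown, compound 3 has the highest, with the nearest being a 59-fold higher number from compound 1 to compound 3 (1.77 log units; beyond the scatter). The value of compound 2 is a limit of the assay, not a number. Compound 4 `COc1cc(-c2ccnc3cc(-c4ccc(N(C)C)cc4)nn23)cc(OC)c1OC` differs from compound 3 by dimethylamino in place of 1-methyl-1H-pyrazol-4-yl on an aromatic carbon. Among the measured compounds shown here, two measured steps bear on this change: a 59-fold higher number from compound 1 to compound 3 (1.77 log units; beyond the scatter) and an at least 8.0-fold lower number from compound 2 to compound 3 (0.90 log units; beyond the scatter). The group that enters counts fewer heavy atoms than the one that leaves, and the methyl of compound 1 goes with 21 nM in this assay. Compound 4 is therefore expected to give a lower number than compound 3, an estimated 6.2-fold lower number from compound 3 to compound 4 (0.79 log units; beyond the scatter). The estimate for compound 4 is 200 nM, ranging from 30 nM to 2000 nM.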

Compound 4, half-maximal inhibitory concentration: 702 nM
For compound 4 the middle estimate is 3.5-fold (0.55 log units) below the measured one, and the stated range covers the measured number.
By their numbers in this assay, from the lowest: compound 1; then compounds 4 and 3 (each within the scatter of the next). At a limit, above all of these: compound 2.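

In this assay, dimethylamino and 1-methyl-1H-pyrazol-4-yl are not told apart at this position, despite the difference in heavy atoms and the loss of the ring: a 1.8-fold lower number from compound 3 to compound 4 (0.25 log units; within the scatter). Dimethylamino stays well short of methyl, a 33-fold higher number from compound 1 to compound 4 (1.52 log units; beyond the scatter), yet it clearly improves on tert-butyl, an at least 14-fold lower number from compound 2 to compound 4 (1.15 log units; beyond the scatter). Compound 2 gives a limit and not a number: the limit of > 10000 nM in this assay, at which 1 of the 4 values shown sits.

The compounds shown leave open whether an ethyl group, a methoxy group or a primary amine at this position would stay close to compound 1.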